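Chloro added to a compound at the assay limit

The source may report more compounds than this note shows. Statements on the series, on what has been measured and on what is new or still open speak of the compounds shown alone.

In a functional assay on U-251 cells (Homo sapiens) for cytotoxicity, read by sulforhodamine B assay, with a stated time of 48 h (a lower number here means a stronger inhibitor, a higher number a weaker inhibitor), compound 3 `CC1(C)CNC(=O)c2cc3n(c2C1)CCc1ccccc1-3` gives > 100000 nM, which is a limit and not a number. Compound 4 `CC1(C)CNC(=O)c2cc3n(c2C1)CCc1cc(Cl)ccc1-3`, not yet measured, carries chloro in place of hydrogen on an aromatic carbon. Two halogen-bearing relatives give numbers: compound 1 `CC1(C)CNC(=O)c2cc(-c3ccc([N+](=O)[O-])cc3)n(-c3ccc(Cl)cc3)c2C1` gives 28800 nM and compound 2 `CC1(C)CNC(=O)c2cc(-c3ccc([N+](=O)[O-])cc3)n(-c3ccc(Br)cc3)c2C1` gives 25600 nM. Among the measured compounds shown here, the only measured step, bromo in place of chloro, is a 1.1-fold lower number from compound 1 to compound 2 (0.05 log units; within the scatter). That step swaps one halogen for another, so it offers only weak guidance on adding chloro in place of hydrogen. A small move toward a lower number is expected, perhaps none beyond the scatter, expressed as an estimated at least 1.2-fold lower number from compound 3 to compound 4 (0.09 log units; that floor lies within the scatter). For compound 4 the expected value is 80000 nM, with an estimated range from 30000 nM to 160000 nM.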

Compound 4, half-maximal inhibitory concentration: > 100000 nM
Compound 4 ended at the assay's limit; the forecaster's own chance of this, stated with the estimate: 50%; middle value at least 1.2-fold (0.09 log units) from the limit.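

Compound 3 and compound 4 both give only a limit and not a number, so the step between them cannot be read: the limit of > 100000 nM in this assay, at which 2 of the 4 values shown sit.

As far as these compounds go, whether chloro in place of hydrogen on an aromatic carbon changes the cytotoxicity of this pair at all remains open.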